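The compounds below may be only part of what the source reports. "The series", "measured", "known", "first", "only" and "open" are said of these compounds alone.

Of the compounds shown here, three of one series have been measured in a functional assay on U-87MG ATCC cells for antiproliferative activity against U-87 MG (Homo sapiens), read by MTT assay, with a stated time of 48 h, tested at 100 uM; a lower number here means a stronger effect, a higher number a weaker effect of the compound at the concentration tested. Compound 1 `Cc1nc(-c2ccc(Cl)cc2)sc1C(=O)CSc1nc(-c2ccc(Cl)c(Cl)c2)c(C#N)c(=O)[nH]1` gives 36.5% in this assay. Compound 2 `Cc1nc(-c2ccccc2)sc1C(=O)CSc1nc(-c2ccccc2)c(C#N)c(=O)[nH]1` gives 9.23%. Compound 3 `COc1ccc(-c2nc(SCC(=O)c3sc(-c4ccc(Cl)cc4)nc3C)[nH]c(=O)c2C#N)cc1OC` gives 18.7%, the second highest of the three numbers: compound 2 lies nearest, within the scatter, while compound 1 lies furthest, beyond it. Among the compounds with values here, the only single change measured so far, a number 17.8 percentage points lower from compound 1 to compound 3 (beyond the scatter), shows a modest move to a lower number.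

Compound 4 `Cc1nc(-c2ccc(Cl)cc2)sc1C(=O)CSc1nc(-c2ccccc2)c(C#N)c(=O)[nH]1` has not been measured. It differs from compound 3 at one place: phenyl in place of 3,4-dimethoxyphenyl on an aromatic carbon. Within the data shown here, no measured step covers this exact exchange. The step from compound 1 to compound 3 bears on it only loosely, since it concerns the same place but another pair of groups. Compound 2 carries a phenyl at that same place, and its number is the lowest shown, but compound 2 also differs from compound 4 elsewhere, so its value can only hint. Compound 4 is therefore expected to give 14%, with a range from 5% to 30%. This estimate means a step of a number 4.7 percentage points lower from compound 3 to compound 4 (within the scatter), expected to fall within or near the edge of the scatter.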

Compound 4, a percentage reported as activity, at one concentration (the size of the read-out at that concentration, not a potency): 11.4%
The estimate for compound 4 lay 2.6 percentage points above the measured number; low and high end bracket the measured number.
By their numbers in this assay, from the lowest: compounds 2, 4 and 3 (each within the scatter of the next); then compound 1.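

At the aromatic carbon ortho to a cyano group, in this assay, phenyl in place of 3,4-dimethoxyphenyl gives a number 7.3 percentage points lower from compound 3 to compound 4 (within the scatter), so these two groups are not told apart here, whereas phenyl in place of 3,4-dichlorophenyl gives a number 25.1 percentage points lower from compound 1 to compound 4 (beyond the scatter), which sets the 3,4-dichlorophenyl compound apart from the phenyl compound at this position. A second exchange, away from this position, can now also be read: chloro in place of hydrogen on an aromatic carbon gives a number 2.2 percentage points higher from compound 2 to compound 4 (within the scatter), so that chloro makes no distinction between these two compounds in this assay. Nothing measured alongside these numbers bears on why the groups at this position behave as they do.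

The compounds shown leave open whether one chloro alone, on that phenyl ring, would be enough to separate a compound from the phenyl compound, or whether both chloro groups of the 3,4-dichlorophenyl are needed. They also leave open how a phenyl ring carrying an amine or a carboxylic acid would read at this position, and, with only a single tested concentration, how the compounds would rank by potency.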